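Ester side chain variation in angiotensin II type-2 binders

The compounds below may be only part of what the source reports. "The series", "measured", "known", "first", "only" and "open" are said of these compounds alone.

compound 1 `CCCc1nc(CC)c(C(=O)OCc2ccccc2OCCC(C)C)n1Cc1ccc(-c2ccccc2S(=O)(=O)NC(=O)OCCC(C)C)cc1F`: 10 nM
compound 2 `CCCc1nc(CC)c(C(=O)OCc2ccccc2-c2ccccc2)n1Cc1ccc(-c2ccccc2S(=O)(=O)NC(=O)OCCC(C)C)cc1F`: 9 nM

In an assay on isolated protein for binding affinity to Type-2 angiotensin II receptor (Homo sapiens) (a lower number here means a stronger inhibitor, a higher number a weaker inhibitor), compound 2 gives 9 nM and stands at one end of the pair, within the scatter of compound 1 at 10 nM. Compound 3 `CCCc1nc(CC)c(C(=O)OCCCCOc2ccccc2)n1Cc1ccc(-c2ccccc2S(=O)(=O)NC(=O)OCCC(C)C)cc1F` carries 3-phenoxypropyl in place of 2-phenylphenyl on a saturated chain carbon bound to an oxygen next to a carbonyl group. Among the compounds with values here, the only measured step, a 1.1-fold lower number from compound 1 to compound 2 (0.05 log units; within the scatter), exchanged one substituent on an aromatic carbon and stayed within the scatter; no step replaces the ring itself with a chain, so it bears only loosely here. Compound 3 is therefore expected near compound 2, with room for a modest loss: estimate 20 nM, range 6 nM to 70 nM, an expected step of a 2.2-fold higher number from compound 2 to compound 3 (0.35 log units; beyond the scatter).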

Compound 3, half-maximal inhibitory concentration: 2 nM
Compound 3: the middle estimate sits 10-fold (1.00 log units) above what was measured; the measured number lies below the stated range.
By their numbers in this assay, from the lowest: compound 3; then compounds 2 and 1 (each within the scatter of the next).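

In this assay the move to 3-phenoxypropyl on a saturated chain carbon bound to an oxygen next to a carbonyl group gives a 4.5-fold lower number from compound 2 to compound 3 (0.65 log units; beyond the scatter) when 2-phenylphenyl leaves and a 5.0-fold lower number from compound 1 to compound 3 (0.70 log units; beyond the scatter) when 2-(isopentyloxy)phenyl leaves, so this position responds beyond the scatter, unlike the earlier exchange on the aromatic carbon. The second aromatic ring of 2-phenylphenyl is not required for a low number here. Nothing available accounts for this gain.

Going by these compounds, whether the gain follows the oxygen of 3-phenoxypropyl or its chain stays open; an all-carbon phenylbutyl chain or a chain ending in an amine would bear on this.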